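Replacing the methylpiperazine tail with dimethylamine

The compounds below may be only part of what the source reports. "The series", "measured", "known", "first", "only" and "open" are said of these compounds alone.

Compound 1 `Cc1ccccc1-c1nn(C(C)C)cc1CNCCN1CCN(C)CC1` — > 20000 nM
Compound 2 `Cc1ccccc1-c1nn(-c2ccc(F)cc2F)cc1CNCCN1CCN(C)CC1` — > 20000 nM
Compound 3 `CSc1ccc(-n2cc(CNCCN3CCN(C)CC3)c(-c3ccccc3C)n2)cc1` — 17000 nM

Three compounds share one core and differ only in the group on an aromatic nitrogen. In an ADME assay on Huh-7 cells (Homo sapiens) for cytotoxicity (a higher number here means that more compound is tolerated, a lower number that less compound is tolerated), compound 1 reaches only the limit of the assay, > 20000 nM. Compound 2 likewise reaches only the limit, > 20000 nM. Compound 3 gives a number, 17000 nM. The step that the two limits leave unreadable from compound 1 to compound 2 cannot be read. The steps of an at least 1.1-fold lower number from compound 1 to compound 3 (0.07 log units; that floor lies within the scatter) and an at least 1.1-fold lower number from compound 2 to compound 3 (0.07 log units; that floor lies within the scatter) have floors that lie within the scatter. Compound 2 thus stands at the limit of > 20000 nM in this assay, at which 2 of the 3 values shown sit.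

Compound 4 `Cc1ccccc1-c1nn(-c2ccc(F)cc2F)cc1CNCCN(C)C` differs from compound 2 by dimethylamino in place of 4-methylpiperazin-1-yl on a saturated chain carbon, two bonds along the chain from an amine nitrogen. Among the measured compounds shown here, none of the three measured steps touches this place; each of them changes the group on the aromatic nitrogen, so no measured step bears on this change. In this assay a step not beyond the scatter is expected, namely a number no higher from compound 2 to compound 4 (the limit leaves the size open). Compound 4 is therefore estimated at 20000 nM, between 10000 nM and 40000 nM, and most likely reported again only as a limit.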

Compound 4, half-maximal cytotoxic concentration: > 20000 nM
Compound 4 gave a limit, no number; the forecaster's own chance of this, stated with the estimate: 70%; the middle value lies on the limit itself.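

In this assay, among the compounds shown here, compound 4 gives only a limit, > 20000 nM; with compound 2 also at a limit, no step between the two can be read. The compounds shown leave open whether dimethylamino in place of 4-methylpiperazin-1-yl alters how much compound is tolerated.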